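Swapping the naphthyloxy arm for an ethoxybenzyl chain

The source may hold more compounds than are shown below. What is called first, only, known or untested is meant among the compounds shown, and "the series" means these compounds.

Measured compounds:
compound 1, `CC(C)C[C@H](N)c1cc(C(F)(F)F)ccc1N1CCN(C(=O)CCC(N)=O)CC1`, > 10000 nM
compound 2, `CC(C)C[C@H](N)c1cc(C(F)(F)F)ccc1N1CCN(C(=O)COc2cccc3ccccc23)CC1`, 2600 nM

Compound 1 is `CC(C)C[C@H](N)c1cc(C(F)(F)F)ccc1N1CCN(C(=O)CCC(N)=O)CC1`; in an assay on HEK293 cells for displacement of a labelled ligand from Melanocortin receptor 4 (Homo sapiens) (on this read-out lower numbers stand for stronger inhibition and higher numbers for weaker inhibition), compound 1 is reported only as a limit of the assay, > 10000 nM. Among the compounds with values here, compound 2, `CC(C)C[C@H](N)c1cc(C(F)(F)F)ccc1N1CCN(C(=O)COc2cccc3ccccc23)CC1`, is the one compound with a real number in this assay, where compound 2 gives 2600 nM. Within the data shown here, the single measured step, an at least 3.8-fold lower number from compound 1 to compound 2 (0.58 log units; beyond the scatter), is bounded by the limit of > 10000 nM in this assay, at which 1 of the 2 values shown sits, so only its lower bound is known.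

Compound 3 is `CCOc1cccc(CC(C)C(=O)N2CCN(c3ccc(C(F)(F)F)cc3[C@@H](N)CC(C)C)CC2)c1`. It differs from compound 2 by 1-(3-ethoxybenzyl)ethyl in place of ((naphthalen-1-yl)oxy)methyl on a carbonyl carbon. Among the measured compounds shown here, no measured step matches this change, and the only step available, an at least 3.8-fold lower number from compound 1 to compound 2 (0.58 log units; beyond the scatter), concerns a different exchange at the same carbonyl carbon; it tells that an aromatic-bearing group there gives a lower number than carbamoylmethyl, and compound 3 keeps an aromatic ring. On that basis the step from compound 2 to compound 3 is expected to be small, a 1.3-fold lower number from compound 2 to compound 3 (0.11 log units; within the scatter), and not clearly beyond the scatter in either direction. For compound 3 the estimated value in this assay is 2000 nM, expected to fall between 600 nM and 7000 nM.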

Compound 3, inhibition constant: 2200 nM
Beside the measured number, compound 3's estimate is 1.1-fold (0.04 log units) below it, within the range that was stated.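

In this assay the exchange gives a 1.2-fold lower number from compound 2 to compound 3 (0.07 log units; within the scatter), so 1-(3-ethoxybenzyl)ethyl and ((naphthalen-1-yl)oxy)methyl on this carbonyl carbon cannot be told apart, even though the entering group has one six-membered aromatic ring of carbon only where the leaving group has two. Set against the 2-carbamoylethyl group, the same entering group gives an at least 4.5-fold lower number from compound 1 to compound 3 (0.65 log units; beyond the scatter), which makes it a second aromatic-bearing group at this place, after the one in compound 2, with a number clearly lower than that of compound 1. Only a lower bound is known for this step, because the value of compound 1 is a limit of the assay: the limit of > 10000 nM in this assay, at which 1 of the 3 values shown sits.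

On these data alone, it stays open whether a plain benzyl without the ethoxy group, or a carboxylic acid or primary amine at the end of a longer chain on this carbonyl carbon, would shift the number. The separate contributions of the ethoxy group and the methyl branch within 1-(3-ethoxybenzyl)ethyl also remain unresolved, since no pair shown isolates either one.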